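Methyl for Hydrogen on an Oxygen: Inactivity Preserved

The compounds below may be only part of what the source reports. "The series", "measured", "known", "first", "only" and "open" are said of these compounds alone.

Three compounds sharing a related framework were examined in an ADME assay on MRC5 cells (Homo sapiens) for inhibition, read by MTT assay, with a stated time of 72 h; a higher number here means a weaker inhibitor, a lower number a stronger inhibitor. Compound 1 `O=C1C[C@H]2O[C@H]([C@H](O)c3ccccc3)[C@H](O)[C@H]2O1` is the parent of the set. In this assay compound 1 gives > 100000 nM, which is a limit of the assay rather than a number. Compound 3 `CO[C@@H]1[C@H]2OC(=O)C[C@H]2O[C@@H]1[C@H](O)c1ccccc1` differs from compound 1 by methyl in place of hydrogen on an oxygen on a saturated carbon. In this assay compound 3 gives > 100000 nM, again a limit. The step that the two limits leave unreadable from compound 1 to compound 3 therefore cannot be sized, because both of its ends sit at the limit of > 100000 nM in this assay, at which 3 of the 3 values shown sit.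

Compound 2 `CO[C@@H](c1ccccc1)[C@H]1O[C@@H]2CC(=O)O[C@@H]2[C@H]1O` belongs to the same family, but the difference between the cores of compound 1 and compound 2 is not broken down here. In this assay compound 2 gives > 100000 nM, a limit as well.

Compound 4 `CO[C@@H]1[C@H]2OC(=O)C[C@H]2O[C@@H]1[C@@H](OC)c1ccccc1` is not yet measured. It differs from compound 2 by methyl in place of hydrogen on an oxygen on a saturated carbon, the same change that separates compound 1 from compound 3, at the same place. Because every value shown so far rests at the limit of > 100000 nM in this assay, at which 3 of the 3 values shown sit, the step from compound 1 to compound 3 offers no readable direction, and the expectation for compound 4 rests only on the observation that none of the three measured compounds reached a number. Compound 4 is expected to show a step that the limit leaves unreadable from compound 2 to compound 4 in this assay. Compound 4 is estimated at about 200000 nM, with a wide range from 50000 nM to 1000000 nM, and most probably it will again be reported only as a limit.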

Compound 4, half-maximal inhibitory concentration: 87600 nM
Beside the measured number, compound 4's estimate is 2.3-fold (0.36 log units) above it; the measured number falls inside the stated range.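

In this assay, among these compounds, the change of hydroxy to methoxy gives an at least 1.1-fold lower number from compound 2 to compound 4 (0.05 log units; that floor lies within the scatter), and this is the only step in the set with a readable size. The same change on the core of compound 1 gives a step that cannot be read, and no comparison of size between the two cores is possible, because both ends of that step rest at a limit: the limit of > 100000 nM in this assay, at which 3 of the 4 values shown sit. The result therefore shows that compound 4 reaches a measured number in this cell assay, though the floor of its step does not establish a real change from compound 2, and it does not show that methyl in place of hydrogen has the same effect on both cores or how large the true step from compound 2 is.

The compounds shown leave open how this assay would respond to a longer chain, such as ethyl or propyl, in place of the methyl on this oxygen. They also leave open whether an amine or a carboxylic acid carried on the shared core would move the series away from the limit and give a readable comparison between the two cores.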